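Solubility of a Fluoronaphthyl Pyridinone Series in Buffer

The source may hold more compounds than are shown below. What is called first, only, known or untested is meant among the compounds shown, and "the series" means these compounds.

Measured compounds:
compound 1 `O=C1NC(=O)/C(=C/C(c2ccc(-c3ccc4cccc(F)c4c3)[nH]c2=O)C2CC2)O1` 30800 nM
compound 2 `CC(C)C(c1ccc(-c2ccc3cccc(F)c3c2)[nH]c1=O)C1SC(=O)NC1=O` 20100 nM
compound 3 `CCC(/C=C1\OC(=O)NC1=O)(CC)c1ccc(-c2ccc3cccc(F)c3c2)[nH]c1=O` 32600 nM

In a physicochemical assay for solubility, in phosphate buffer, measured as kinetic solubility (a higher number here means a more soluble compound, a lower number a less soluble compound), compound 2 gives 20100 nM, the lowest of the three numbers. Its gap to compound 1 and its gap to compound 3 both lie within the usual scatter, so the three compounds cannot be told apart on solubility.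

Compound 4 `CC(C)C(/C=C1/C(=O)NC(=O)N1C)c1ccc(-c2ccc3cccc(F)c3c2)[nH]c1=O` has not yet been measured in this assay. It differs from compound 2 in one place: a group of 9 heavy atoms (5 carbon, 2 nitrogen, 2 oxygen; one five-membered non-aromatic ring with 2 hetero atoms) in place of a group of 7 heavy atoms (3 carbon, 1 nitrogen, 2 oxygen, 1 sulfur; one five-membered non-aromatic ring with 2 hetero atoms), on a saturated chain carbon bound to an aromatic carbon and a saturated chain carbon. The 2,4-dioxo-1,3-thiazolidin-5-yl group leaves, and a five-membered non-aromatic ring with two hetero atoms, carrying one hydrogen-bond donor and two hydrogen-bond acceptors, enters on the saturated chain carbon bound to an aromatic carbon and a saturated chain carbon.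

Within the data shown here, no measured pair shows a step of this kind. Compounds 1 and 3 carry related ring groups and sit within the scatter of compound 2, so for this assay no step beyond the scatter is expected, and the estimated step is a 1.2-fold higher number from compound 2 to compound 4 (0.09 log units; within the scatter). Compound 4 is expected to give 25000 nM, with a range from 10000 nM to 60000 nM.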

Compound 4, solubility: 34800 nM
Compound 4: middle estimate off by 1.4-fold (0.14 log units), on the low side; low and high end bracket the measured number.
By their numbers in this assay, from the lowest: compounds 2, 1, 3 and 4 (each within the scatter of the next).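

In this assay, among these compounds, putting the entering ring group in place of the 2,4-dioxo-1,3-thiazolidin-5-yl group, on the saturated chain carbon bound to an aromatic carbon and a saturated chain carbon, gives a 1.7-fold higher number from compound 2 to compound 4 (0.24 log units; within the scatter) as the first step that can be read at this place. The swap removes the sulfur and takes the group from 7 to 9 heavy atoms, with one hydrogen-bond acceptor fewer and the same single donor, yet the two compounds still cannot be told apart. Nothing measured on these compounds offers an explanation for this result.

The compounds shown leave open whether a group of a different kind at this place, such as an amine or a carboxylic acid, would give a step beyond the scatter. A single step also cannot show how far this place tolerates change in general.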